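A few compounds are considered here, and "the series" means these few. Any claim that something is new, unique, unknown or untested is made for them only; others in the source may bear on it.

Compound 1 `CC(C)(C)OC(=O)N1CCC(Oc2ncnc3c2CCN3c2ccc(S(C)(=O)=O)cc2F)CC1` gives 20 nM in a functional assay on CHO-K1 cells for agonist activity at Glucose-dependent insulinotropic receptor (Homo sapiens), read by a luciferase reporter, with a stated time of 5 h; on this read-out higher numbers stand for an effect only at larger amounts of compound and lower numbers for an effect already at smaller amounts.
Compound 2 `COC(=O)N1CCC(Oc2ncnc3c2CCN3c2ccc(S(C)(=O)=O)cc2F)CC1` gives 316 nM in this assay.
Compound 3 `CCS(=O)(=O)N1CCC(Oc2ncnc3c2CCN3c2ccc(S(C)(=O)=O)cc2F)CC1` gives 1580 nM in this assay.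

Among these three compounds, compound 3 gives the highest number in this assay. Its nearest neighbour is compound 2, through the modest step of a 5.0-fold higher number from compound 2 to compound 3 (0.70 log units; beyond the scatter), and its furthest is compound 1, through the large step of a 79-fold higher number from compound 1 to compound 3 (1.90 log units; beyond the scatter). Compound 4 `CC(C)c1noc(N2CCC(Oc3ncnc4c3CCN4c3ccc(S(C)(=O)=O)cc3F)CC2)n1` differs from compound 3 in one place: 3-isopropyl-1,2,4-oxadiazol-5-yl in place of ethylsulfonyl on an amine nitrogen in a ring. Every measured step concerns the group on this same ring nitrogen, so all three bear on the change. The two carbamates give lower numbers than the ethylsulfonyl, and within the carbamates the step of a 16-fold higher number from compound 1 to compound 2 (1.20 log units; beyond the scatter) shows that a tert-butyl on the oxygen gives a far lower number than a methyl. The entering 3-isopropyl-1,2,4-oxadiazol-5-yl has more heavy atoms than the leaving ethylsulfonyl and carries an isopropyl, which on these numbers is expected to bring compound 4 back toward compound 1, a downward step a 53-fold lower number from compound 3 to compound 4 (1.72 log units; beyond the scatter). Compound 4 is therefore estimated at 30 nM, with a range from 6 nM to 150 nM.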

Compound 4, half-maximal effective concentration: 79.4 nM
Beside the measured number, compound 4's estimate is 2.6-fold (0.42 log units) below it, within the range that was stated.
By their numbers in this assay, from the lowest: compound 1; then compound 4; then compound 2; then compound 3.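

Among these compounds, at the amine nitrogen in a ring, the earlier compounds covered only two carbamates and a sulfonyl, and compound 4 now shows that a group with neither a carbonyl nor a sulfonyl can give a low number in this assay: the change to 3-isopropyl-1,2,4-oxadiazol-5-yl brings a 20-fold lower number from compound 3 to compound 4 (1.30 log units; beyond the scatter) and also a 4.0-fold lower number from compound 2 to compound 4 (0.60 log units; beyond the scatter). The one five-membered aromatic ring thus places compound 4 inside the span set by the two carbamates, yet the tert-butyl carbamate keeps the lowest number at this position, as the remaining step shows: a 4.0-fold higher number from compound 1 to compound 4 (0.60 log units; beyond the scatter). Nothing among the data given here accounts for any of these differences.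

The compounds shown do not separate the five-membered ring from its isopropyl, so what a methyl or a tert-butyl on that same ring would give stays open. Also open, from the compounds shown here alone, is how a simple amide, a urea or a pyrimidine ring on this nitrogen would read, and whether the order seen here would hold with another group in place of the methylsulfonyl on the shared core.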